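Replacing the amine tail of compound 1 with a carboxymethyl amide

The source may report more compounds than this note shows. Statements on the series, on what has been measured and on what is new or still open speak of the compounds shown alone.

Compound 1 `CCn1c(C(=O)NCCN)ccc1C(CC)(CC)c1ccc(OCC(=O)C(C)(C)C)c(C)c1` has the higher of the two numbers in an assay on HL-60 cells for agonist activity at vitamin D3 receptor (Homo sapiens), read by microscopy, with a stated time of 96 h (on this read-out lower numbers stand for an effect already at smaller amounts and higher numbers for an effect only at larger amounts of compound), giving 120 nM. Compound 2 `CCn1c(C(=O)NCCN)ccc1C(CC)(CC)c1ccc(OCC(O)C(C)(C)C)c(C)c1` gives 10 nM, and a 12-fold lower number from compound 1 to compound 2 (1.08 log units; beyond the scatter). Compound 3 `CCn1c(C(=O)N(C)CC(=O)O)ccc1C(CC)(CC)c1ccc(OCC(=O)C(C)(C)C)c(C)c1` differs from compound 1 elsewhere: (carboxymethyl)(methyl)amino in place of (2-aminoethyl)amino on a carbonyl carbon. Among the compounds with values here, the one measured step concerns a different part of the shared core, so no measured step bears on this change. For compound 3 the expectation is therefore a step of a 1.3-fold higher number from compound 1 to compound 3 (0.10 log units; within the scatter), not clearly beyond the scatter, and its estimated value in this assay is 150 nM, within 30 nM to 800 nM.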

Compound 3, half-maximal effective concentration: 1390 nM
The estimate for compound 3 lay 9.3-fold (0.97 log units) below the measured number, outside the stated range (above it).
By their numbers in this assay, from the lowest: compound 2; then compound 1; then compound 3.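

With (carboxymethyl)(methyl)amino in place of (2-aminoethyl)amino on the carbonyl carbon, this assay shows a 12-fold higher number from compound 1 to compound 3 (1.06 log units; beyond the scatter) and so this position also moves the number, which the earlier pair, changed only at the other end of the molecule, could not reveal. No accompanying measurement explains the step. The change brings in a carboxylic acid and a methyl on the amide nitrogen together, so the compounds shown do not separate the two. A (carboxymethyl)amino group without that methyl, or a (2-aminoethyl)(methyl)amino group, would tell them apart.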